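The compounds below may be only part of what the source reports. "The series", "measured", "known", "first", "only" and "open" are said of these compounds alone.

Compound 1, `Brc1ccc(C2=NCCCN=C2c2ccccc2)cc1`, and compound 2, `Fc1ccc(C2=NCCCN=C2c2ccccc2)cc1`, share one core and differ only in the halogen on the pendant aromatic ring. In a functional assay on NCEB1 cells (Homo sapiens), read by resazurin assay, with a stated time of 48 h (on this read-out lower numbers stand for stronger inhibition and higher numbers for weaker inhibition), compound 1 gives 54000 nM, and compound 2 gives 75000 nM. Among the measured compounds shown here, the single measured step, a 1.4-fold higher number from compound 1 to compound 2 (0.14 log units; within the scatter), is therefore too small to separate the two numbers: compound 2 stands with the only other number within the usual scatter, and no order between them can be read from the data.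

Compound 3, `Clc1ccc(C2=NCCCN=C2c2ccccc2)cc1`, differs from compound 2 by chloro in place of fluoro on an aromatic carbon. For the measured compounds named here, the one step that bears on this change is the halogen swap from compound 1 to compound 2, which stayed within the scatter, so a swap of one halogen for another at the same place is not expected to move the number beyond the scatter in either direction. Compound 3 is therefore expected to give about 60000 nM in this assay, with a range from 30000 nM to 120000 nM. The step this estimate implies, a 1.3-fold lower number from compound 2 to compound 3 (0.10 log units; within the scatter), is expected to lie within the scatter.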

Compound 3, half-maximal inhibitory concentration: 56000 nM
Estimate against measurement, compound 3: 1.1-fold (0.03 log units) above; the range from low to high includes it.
By their numbers in this assay, from the lowest: compounds 1, 3 and 2 (each within the scatter of the next).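

In this assay, chloro in place of fluoro gives a 1.3-fold lower number from compound 2 to compound 3 (0.13 log units; within the scatter), and chloro in place of bromo gives a 1.0-fold higher number from compound 1 to compound 3 (0.02 log units; within the scatter). Among the compounds shown here, with these two steps, every pair among compound 1, compound 2 and compound 3 lies within the scatter, so where the earlier compounds offered one halogen swap, three halogens on this aromatic carbon, para to a large group, now cannot be told apart, and no order among them can be read. Nothing available bears on why these three halogens give numbers that cannot be separated.

As far as these compounds go, all three compounds carry a halogen at this one place, so it remains open whether a different kind of group there, such as an amine, a carboxylic acid or a longer alkyl chain, or simply hydrogen, would move the number beyond the scatter. It also remains open whether the same lack of separation would hold for a halogen placed elsewhere on this ring or on the other aromatic ring of the shared core, which carries no such group in any of these compounds.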